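A few compounds are considered here, and "the series" means these few. Any claim that something is new, unique, unknown or untested is made for them only; others in the source may bear on it.

Compound 1, `COc1c(/C=C2/C(=O)Nc3ccc(Cl)cc32)c2ccccc2n1-c1ccccc1`, was examined in a functional assay on cells (Cancer cell lines, Homo sapiens) for cytotoxicity, with a stated time of 48 h (a lower number here means a stronger inhibitor of growth, a higher number a weaker inhibitor of growth), where compound 1 gives 8510 nM. Among the three compounds measured, this places compound 1 second highest. Its nearest neighbour is compound 3, `O=C1/C(=C/c2c(Cl)[nH]c3ccccc23)c2ccccc2N1Cc1ccccc1`, for which compound 3 gives 5250 nM, a gap that lies within the scatter of this assay, so no order between the two can be claimed. The most distant is compound 2, `COc1cc2c(cc1C)NC(=O)/C2=C/c1c(Cl)n(Cc2cc(OC)c(OC)c(OC)c2)c2cc(C)c(OC)cc12`, since compound 2 gives 38900 nM, a gap beyond the scatter.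

The unmeasured compound 4, `COc1ccc2c(c1)/C(=C\c1c(OC)n(-c3ccccc3)c3ccccc13)C(=O)N2`, differs from compound 1 in one place: methoxy in place of chloro on an aromatic carbon. The substituent sits on an aromatic carbon of a six-membered aromatic ring of carbon only, part of a fused system of two rings. Going by the values given here, no measured pair in this set shows the effect of such a replacement, so the direction cannot be read from the data. The step from compound 1 to compound 4 is expected to be small, a 1.4-fold higher number from compound 1 to compound 4 (0.15 log units; within the scatter), tending toward a weaker inhibitor of growth but possibly within the scatter. Compound 4 is therefore estimated at 12000 nM, with a range from 4000 nM to 36000 nM.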

Compound 4, concentration for 50% growth inhibition: 2290 nM
The estimate for compound 4 lay 5.2-fold (0.72 log units) above the measured number; measured number outside the range, below it.
By their numbers in this assay, from the lowest: compound 4; then compounds 3 and 1 (each within the scatter of the next); then compound 2.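

In this assay, replacing chloro with methoxy on this aromatic carbon of the six-membered ring gives a step beyond the scatter, a 3.7-fold lower number from compound 1 to compound 4 (0.57 log units; beyond the scatter), so the substituent at this position of the core of compound 1 does affect growth inhibition. Going by these compounds alone, this is the only comparison in the set that changes one place, so the finding that methoxy gives a stronger inhibitor of growth than chloro here rests on this single pair and this single core. Nothing available explains the direction of the step.

From the compounds shown here alone, whether an amine or a longer chain such as ethoxy on the same carbon would give a lower or higher number remains open. So does whether the same exchange would move the number in the same direction on the cores of compound 2 and compound 3.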